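A phenyl swap from compound 2 to compound 4

This account rests on a few compounds, and the source may have more. Where it says the series, first, only, none or still open, it means among the compounds named here.

compound 1 `Cc1ccc(NC(=O)Nc2cccc(-c3cccc4[nH]nc(N)c34)c2)cc1` gives 1660 nM
compound 2 `Nc1n[nH]c2cccc(-c3cccc(NC(=O)Nc4ccc(F)c(F)c4)c3)c12` gives 3040 nM
compound 3 `Nc1n[nH]c2cccc(-c3cccc(NC(=O)Nc4cc(C(F)(F)F)cc(C(F)(F)F)c4)c3)c12` gives 1510 nM

All three values come from a functional assay on A549 cells (Homo sapiens) for inhibition, read by MTT assay, with a stated time of 48 h (on this read-out lower numbers stand for stronger inhibition and higher numbers for weaker inhibition), and lie within the scatter of one another. Compound 2 at 3040 nM does not separate from compound 1 or compound 3 on these numbers.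

Compound 4 `Nc1n[nH]c2cccc(-c3cccc(NC(=O)Nc4cccc(Cl)c4)c3)c12` is not yet measured. It carries 3-chlorophenyl in place of 3,4-difluorophenyl on an amide-type nitrogen and keeps the shared core.

Within the data shown here, the only measured step at this nitrogen is a 1.8-fold higher number from compound 1 to compound 2 (0.26 log units; within the scatter) and it serves as the closest guide. Compound 3, also different at this nitrogen, gives 1510 nM and stays within the scatter of compound 2 as well. No step beyond the scatter is therefore expected in this assay, and the data fix no firm direction. The expected step is a 1.5-fold lower number from compound 2 to compound 4 (0.18 log units; within the scatter) and it is estimated to stay within the scatter. The estimated value for compound 4 is 2000 nM (expected range 1000 nM to 4000 nM).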

Compound 4, half-maximal inhibitory concentration: 1720 nM
For compound 4 the middle estimate is 1.2-fold (0.07 log units) above the measured one; the measured number falls inside the stated range.
By their numbers in this assay, from the lowest: compounds 3, 1, 4 and 2 (each within the scatter of the next).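

In this assay, 3-chlorophenyl on the amide-type nitrogen gives a 1.8-fold lower number from compound 2 to compound 4 (0.25 log units; within the scatter) and a 1.0-fold higher number from compound 1 to compound 4 (0.02 log units; within the scatter), so neither step separates it from 3,4-difluorophenyl or 4-methylphenyl. With compound 4 added, four different aryl groups at this nitrogen, carrying methyl, fluorine, chlorine or trifluoromethyl, all remain within the scatter of their neighbours in the order of values, and the chlorine-bearing ring adds no new level to the series. Nothing available bears on why these values sit so close together.

Still open, from the compounds shown here alone, is whether this flat picture holds for groups of another kind on this nitrogen, such as a pyridine ring, a carboxylic acid or a longer amine-bearing chain in place of the substituted phenyl. Also open, going by these compounds, is whether these four compounds stay together on any read-out other than this assay.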